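Working notes on cytotoxicity across four related compounds

This account rests on a few compounds, and the source may have more. Where it says the series, first, only, none or still open, it means among the compounds named here.

Measured in an ADME assay on Vero cells (Chlorocebus sabaeus) for cytotoxicity, read by sulforhodamine B assay, with a stated time of 3 days; on this read-out higher numbers stand for lower toxicity in this test and lower numbers for higher toxicity in this test:
- compound 1 `CC1=C(C(=O)Nc2ccc(Cl)cc2)C(C/C=C/c2ccccc2)C(C(=O)Nc2ccc(Cl)cc2)=C(C)N1` gives 21 ug/mL
- compound 2 `CC1=C(C(=O)Nc2ccc(Cl)cc2)C(c2ccccc2O)C(C(=O)Nc2ccc(Cl)cc2)=C(C)N1` gives 62 ug/mL
- compound 3 `COc1ccc(NC(=O)C2=C(C)NC(=O)NC2c2ccccc2O)cc1` gives 160 ug/mL

Compound 1 and compound 2 share one core and differ in a single place: 3-phenylprop-2-en-1-yl in place of 2-hydroxyphenyl on a saturated ring carbon. That exchange gives a 3.0-fold lower number from compound 2 to compound 1 (0.47 log units; beyond the scatter), so the cinnamyl-type group goes with a lower number, that is, higher toxicity in this test.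

Compound 3 stands highest of the three measured numbers, beyond the scatter against both compound 2 and compound 1. Its core is not the core of compound 2; the difference between the two cores is not broken down here.

Compound 4 `COc1ccc(NC(=O)C2=C(C)NC(=O)NC2C/C=C/c2ccccc2)cc1` is the not yet measured partner of compound 3, and differs from it by 3-phenylprop-2-en-1-yl in place of 2-hydroxyphenyl on a saturated ring carbon. Going by the values given here, this is the same kind of change as the one from compound 2 to compound 1, but not the same: in compound 3 the saturated ring carbon sits in a six-membered non-aromatic ring with 2 nitrogen, next to the ring nitrogen, next to the ring atom that bears a large group and two ring bonds from the ring atom that bears a methyl group, whereas in compound 2 the ring holds 1 nitrogen and the carbon sits next to two ring atoms that each bear a (4-chlorophenyl)carbamoyl group.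

Among the compounds with values here, the expectation for compound 4 is a step of about a 2.7-fold lower number from compound 3 to compound 4 (0.43 log units; beyond the scatter), a lower number than compound 3 shows, because a 3.0-fold lower number from compound 2 to compound 1 (0.47 log units; beyond the scatter) is the only guide available for this exchange. Compound 4 is therefore estimated at 60 ug/mL, with a plausible range from 25 ug/mL to 130 ug/mL.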

Compound 4, half-maximal cytotoxic concentration: 15 ug/mL
Estimate against measurement, compound 4: 4.0-fold (0.60 log units) above; measured number below the stated range.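

In this assay the exchange of 2-hydroxyphenyl for 3-phenylprop-2-en-1-yl runs the same way on both cores, towards a lower number and so higher toxicity in this test, and on the core of compound 3 it gives an 11-fold lower number from compound 3 to compound 4 (1.03 log units; beyond the scatter). The direction therefore carries over between these two cores, but the size does not, and the step from one core cannot be transferred to the other as a fixed amount: the same change on two cores in this assay, a 3.0-fold lower number (0.47 log units; beyond the scatter) from compound 2 to compound 1 and an 11-fold lower number (1.03 log units; beyond the scatter) from compound 3 to compound 4, 3.6-fold (0.56 log units) apart, beyond the scatter of two such steps
This rests on a single pair per core, and the two cores differ in more than one place at once, so the gap between the steps cannot be assigned to any one of those differences, nor do two pairs set a rule for a further core.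

The compounds shown leave open whether the larger step belongs to the ring with 2 nitrogen or to the groups carried on it, which a (4-chlorophenyl)carbamoyl group on the core of compound 3 would help to separate. They also leave open whether the exchange depends on the hydroxyl, on the chain or on its double bond, which a plain phenyl or a saturated 3-phenylpropyl chain at the same ring carbon would address.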